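Prenyl chain oxygenation on a quinone core: cytotoxicity notes

This account rests on a few compounds, and the source may have more. Where it says the series, first, only, none or still open, it means among the compounds named here.

Measured so far:
- compound 1 `COc1ccc(O)c2c1C(=O)C=C(CCC=C(C)C)C2=O` gives 2200 nM in a functional assay on SK-BR-3 cells (Homo sapiens) for cytotoxicity, read by MTT assay, with a stated time of 48 h; a lower number here means a stronger inhibitor, a higher number a weaker inhibitor
- compound 2 `COc1ccc(O)c2c1C(=O)C(CCC=C(C)C)=CC2=O` gives 6520 nM in this assay

Compound 1 holds the lowest number of the two; its nearest neighbour, compound 2, sits beyond the scatter with the higher number. Going by the values given here, no single-change step between the two measured compounds is available, so the two values are taken only as they stand.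

Compound 3 `COc1ccc(O)c2c1C(=O)C=C([C@H](CC=C(C)C)OC(C)=O)C2=O` differs from compound 1 in one place: acetoxy in place of hydrogen on a saturated chain carbon bound to a double-bonded ring carbon and a saturated chain carbon. With no measured step of this kind in the set, the direction is uncertain; the step is expected to stay within the scatter, perhaps leaning toward a slightly lower number.

For compound 3 the estimate in this assay is 1800 nM, with a range from 600 nM to 5500 nM, an expected step of a 1.2-fold lower number from compound 1 to compound 3 (0.09 log units; within the scatter) from compound 1.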

Compound 3, half-maximal inhibitory concentration: 440 nM
The estimate for compound 3 lay 4.1-fold (0.61 log units) above the measured number; measured number below the stated range.
By their numbers in this assay, from the lowest: compound 3; then compound 1; then compound 2.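

A step of a 5.0-fold lower number from compound 1 to compound 3 (0.70 log units; beyond the scatter) in this assay comes with acetoxy in place of hydrogen on a saturated chain carbon bound to a double-bonded ring carbon and a saturated chain carbon. Going by these compounds alone, this is the first single-change step, and it shows that this chain carbon carries a group of this size with no loss in the read-out and that the number responds to a change there beyond the scatter, which the two earlier compounds could not show. No measurement in hand bears on the reason for this step.

From the compounds shown here alone, whether the lower number belongs to the acetoxy group itself or to any oxygen on this carbon stays open, and a free hydroxyl, a longer ester such as butyrate or an amine at the same carbon would separate these readings. Also open, going by these compounds, is whether the same acetoxy change on the chain of compound 2 would move the number in the same direction.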